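The compounds below may be only part of what the source reports. "The series", "measured", "known", "first", "only" and "open" are said of these compounds alone.

Series in a functional assay on T98G cells (Homo sapiens) for cytotoxicity, read by MTT assay, with a stated time of 48 h (a lower number here means a stronger inhibitor, a higher number a weaker inhibitor), values so far:
- compound 1 `C/C(=N\NC(=S)Nc1ccc(I)cc1)c1ccccn1`: 64 nM
- compound 2 `CC(=NNC(=S)Nc1cccc(I)c1)c1ccccn1`: 61 nM
- compound 3 `C/C(=N/NC(=S)Nc1ccccc1[N+](=O)[O-])c1ccccn1`: 6.61 nM

Compound 1 holds the highest of the three numbers, though compound 2 lies within the scatter of it, so these two iodo compounds cannot be separated in this assay. Compound 3 lies well beyond the scatter on the lower side of compound 1 .

The next compound to be read is compound 4 `C/C(=N\NC(=S)Nc1ccc([N+](=O)[O-])cc1)c1ccccn1`, which departs from compound 1 in one place: nitro in place of iodo on an aromatic carbon, para to a large group (nitro in place of iodo on an aromatic carbon). Going by the values given here, no pair of measured compounds differs in one place only, so the size of this step has no direct precedent here. Among the compounds with values here, the only guide is compound 3 , which also bears a nitro group and gives 6.61 nM. That is a single compound with the nitro group placed differently, so the expectation stays loose. A lower number than that of compound 1 is expected, with a real chance that the step stays within the scatter. The expected step is a 3.2-fold lower number from compound 1 to compound 4 (0.51 log units; beyond the scatter), and it may prove smaller than the gap seen with compound 3 .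

For compound 4 the estimated value in this assay is 20 nM, with an expected range of 5 nM to 70 nM.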

Compound 4, half-maximal inhibitory concentration: 140 nM
Compound 4: the middle estimate sits 7.0-fold (0.85 log units) below what was measured; measured number outside the range, above it.
By their numbers in this assay, from the lowest: compound 3; then compounds 2 and 1 (each within the scatter of the next); then compound 4.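

In this assay, going by these compounds alone, this is the first single-place step, and it shows that nitro in place of iodo on an aromatic carbon, para to a large group, does not lower the number: a 2.2-fold higher number from compound 1 to compound 4 (0.34 log units; beyond the scatter), a modest move upward. Within the data shown here, a nitro group on the ring is therefore no guarantee of a low number, since compound 4 bears one and compound 3, with its nitro group placed differently, stands on its own at 6.61 nM, with no single-place step linking it to any other compound. No measurement at hand bears on why the swap of iodo for nitro moves the number this way.

Still open, as far as these compounds go, is how far this position tolerates change at all, for instance whether an amine, a methoxy group or a carboxylic acid in the same place would shift the number in this assay more than this step does. Also open, from the compounds shown here alone, is what the place of the nitro group contributes on its own, as that needs a pair of compounds differing in that one place only.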